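The compounds below may be only part of what the source reports. "The series", "measured", "known", "first", "only" and "open" are said of these compounds alone.

Working notes on the series. The shared core is held constant and the group on the aromatic nitrogen is varied. Compound 1 `Cc1cc(NC(=O)Cn2nnc(-c3ccccc3)n2)n(C2CCOCC2)n1` carries oxan-4-yl; in an assay on HEK293 cells for activation of Kir3.1/Kir3.2 (Homo sapiens), read by thallium flux (on this read-out higher numbers stand for an effect only at larger amounts of compound and lower numbers for an effect already at smaller amounts), compound 1 gives 435 nM. Compound 2 `Cc1cc(NC(=O)Cn2nnc(-c3ccccc3)n2)n(C2CCC(F)(F)CC2)n1` carries 4,4-difluorocyclohexyl; in this assay compound 2 gives 84 nM, which is a 5.2-fold lower number from compound 1 to compound 2 (0.71 log units; beyond the scatter). Compound 3 `Cc1cc(NC(=O)Cn2nnc(-c3ccccc3)n2)n(C2CC2)n1` carries cyclopropyl. In this assay compound 3 returns only a limit, > 5000 nM, the same limit as the limit of > 5000 nM in this assay, at which 1 of the 3 values shown sits. Compound 3 thus stands at the weak end of the measured set: an at least 11-fold higher number from compound 1 to compound 3 (1.06 log units; beyond the scatter), and an at least 59-fold higher number from compound 2 to compound 3 (1.77 log units; beyond the scatter).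

Compound 4 `Cc1cc(NC(=O)Cn2nnc(-c3ccccc3)n2)n(CC2CCCCC2)n1` is not yet measured. Its change from compound 3 is cyclohexylmethyl in place of cyclopropyl on an aromatic nitrogen. Two measured steps bear on it, both running from a six-membered ring group to cyclopropyl, and both were large, as given above. Among the compounds with values here, compound 4 moves back to a six-membered ring group, though one joined through a methylene, which no measured compound shows. A large step downward is therefore expected, an at least 16-fold lower number from compound 3 to compound 4 (1.22 log units; beyond the scatter). Compound 4 in this assay is estimated at 300 nM, within a range of 60 nM to 2500 nM.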

Compound 4, half-maximal effective concentration: 176 nM
Compound 4: the middle estimate sits 1.7-fold (0.23 log units) above what was measured; the range from low to high includes it.
By their numbers in this assay, from the lowest: compound 2; then compound 4; then compound 1. At a limit, above all of these: compound 3.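

Placing cyclohexylmethyl instead of cyclopropyl on the aromatic nitrogen gives, in this assay, an at least 28-fold lower number from compound 3 to compound 4 (1.45 log units; beyond the scatter), so this position also accepts a six-membered ring joined through a methylene, which no earlier compound showed. Against the two six-membered ring groups joined directly, the readings are a 2.1-fold higher number from compound 2 to compound 4 (0.32 log units; beyond the scatter) and a 2.5-fold lower number from compound 1 to compound 4 (0.39 log units; beyond the scatter), so in this set cyclohexylmethyl ranks behind 4,4-difluorocyclohexyl and ahead of oxan-4-yl. Compound 3 remains a limit of the assay and not a number: the limit of > 5000 nM in this assay, at which 1 of the 4 values shown sits.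

Still open, as far as these compounds go, is what plain cyclohexyl, joined directly to the aromatic nitrogen, would give beside cyclohexylmethyl, and so whether the methylene itself counts for anything at this position. Also open, from the compounds shown here alone, is how this position would respond to a longer link such as cyclohexylethyl, to an open-chain group such as isobutyl, or to a ring carrying an amine such as piperidin-4-yl.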